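Replacing a chlorophenyl arm with a branched alkyl chain

The source may report more compounds than this note shows. Statements on the series, on what has been measured and on what is new or still open speak of the compounds shown alone.

Compound 3 `O=C(O)c1ccccc1-c1ccc(CCc2ncc(Cc3ccc(Cl)cc3)[nH]2)cc1` gives the lowest number of the three compounds in an in vitro functional assay on cells for agonist activity at Bombesin receptor subtype-3 (Mus musculus), read by luminescence and calcium flux (on this read-out lower numbers stand for an effect already at smaller amounts and higher numbers for an effect only at larger amounts of compound), with 102 nM; compound 1 `CCCCc1cnc(C(CCC)Cc2ccc(-c3ccccc3C(=O)O)cc2)[nH]1` gives 165 nM, and compound 2 `CCCCc1cnc(C(Cc2ccc(-c3ccccc3C(=O)O)cc2)C(C)C)[nH]1` gives 2240 nM. For the measured compounds named here, the one measured step, a 14-fold higher number from compound 1 to compound 2 (1.13 log units; beyond the scatter), concerns a change at a different place, so no measured step bears directly on the change from compound 3 to compound 4 `CCC(C)(CC)Cc1cnc(CCc2ccc(-c3ccccc3C(=O)O)cc2)[nH]1`, which is 1-ethyl-1-methylpropyl in place of 4-chlorophenyl on a saturated chain carbon bound to an aromatic carbon. Compound 1 and compound 3, with a saturated chain on the one and an aromatic ring on the other at that place, differ in two places and read close to each other. A modest rise is therefore expected, a 2.9-fold higher number from compound 3 to compound 4 (0.47 log units; beyond the scatter), with wide uncertainty. Compound 4 is estimated at 300 nM, between 80 nM and 1200 nM.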

Compound 4, half-maximal effective concentration: 30 nM
For compound 4 the middle estimate is 10-fold (1.00 log units) above the measured one; measured number below the stated range.
By their numbers in this assay, from the lowest: compound 4; then compounds 3 and 1 (each within the scatter of the next); then compound 2.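

At this position, on a saturated chain carbon bound to an aromatic carbon, an aromatic ring is not needed for a low number: with 1-ethyl-1-methylpropyl in place of 4-chlorophenyl, the reading shows a 3.4-fold lower number from compound 3 to compound 4 (0.53 log units; beyond the scatter) and the ring-free group outperforms the ring. For the compounds shown here, this is the first step read at this position, since the earlier step concerned a different place. No measured evidence explains the change.

The compounds shown leave open whether a smaller branched group such as tert-butyl, or an unbranched longer chain such as hexyl, would serve equally well here. They also leave open whether an amine at this place would be tolerated.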